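Second heptyl chain on the aminoglycoside-type series

The compounds below may be only part of what the source reports. "The series", "measured", "known", "first", "only" and "open" are said of these compounds alone.

Compound 3 `CCCCCCCO[C@@H]1[C@@H](O)[C@H](O[C@H]2O[C@H](CN)[C@@H](O)[C@H](O)[C@H]2N)[C@@H](N)C[C@H]1N` gives 84.3% in an ADME assay on J774 cells (Mus musculus) for cytotoxicity, read by MTT assay, with a stated time of 24 h, tested at 10 uM; a higher number here means a weaker effect of the compound at the concentration tested, a lower number a stronger effect. Compound 1 `CCCCCCCCCO[C@@H]1[C@@H](N)[C@@H](O[C@H]2[C@H](O)[C@@H](O)[C@H](N)C[C@@H]2N)O[C@H](CN)[C@H]1OCCCCCCCCC`, which carries two nonyl chains on its core, gives 82.7%, and compound 2 `CCCCCCCCCCCO[C@@H]1[C@@H](O)[C@H](O[C@H]2O[C@H](CN)[C@@H](O)[C@H](O)[C@H]2N)[C@@H](N)C[C@H]1N` gives 74.7%; both numbers lie within the scatter of compound 3. Among the measured compounds shown here, the only single-place step measured so far, a number 9.6 percentage points higher from compound 2 to compound 3 (within the scatter), concerns the length of one chain and stays within the scatter.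

Compound 4 `CCCCCCCO[C@@H]1[C@@H](N)[C@@H](O[C@H]2[C@H](O)[C@@H](OCCCCCCC)[C@H](N)C[C@@H]2N)O[C@H](CN)[C@H]1O` differs from compound 3 by heptyl in place of hydrogen on an oxygen on a saturated carbon; cut one bond further out, the change reads hydroxy to heptyloxy. For the measured compounds named here, no measured step covers the entry of a second chain on an oxygen. The closest hint is compound 1, where two chains on the core give 82.7%, a number within the scatter of compound 3, so no step beyond the scatter is expected in this assay.

Compound 4 is therefore estimated at 78%, with a range of 60% to 92%, which means an expected step of a number 6.3 percentage points lower from compound 3 to compound 4 (within the scatter).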

Compound 4, a percentage reported as activity, at one concentration (the size of the read-out at that concentration, not a potency): 96.3%
For compound 4 the middle estimate is 18.3 percentage points below the measured one, outside the stated range (above it).
By their numbers in this assay, from the lowest: compounds 2, 1 and 3 (each within the scatter of the next); then compound 4.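

In this assay, among the compounds shown here, heptyl in place of hydrogen on an oxygen on a saturated carbon gives a number 12 percentage points higher from compound 3 to compound 4 (beyond the scatter), and this is the first step printed as beyond the scatter. It runs toward a weaker effect at the concentration tested, so at this position the change from hydroxy to heptyloxy does not strengthen the effect in this assay, whereas the earlier step on chain length, a number 9.6 percentage points higher from compound 2 to compound 3 (within the scatter), could not be told from the scatter. Nothing at hand accounts for the size or direction of this step.

From the compounds shown here alone, the reading rests on a single pair, so it remains open whether it holds for other chains on this oxygen. Also open, going by these compounds, is what an amine or a carboxylic acid at the end of the second heptyl chain would do to this number.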